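A benzylsulfanyl analogue of two compounds at the assay limit

A few compounds are considered here, and "the series" means these few. Any claim that something is new, unique, unknown or untested is made for them only; others in the source may bear on it.

Compound 1 `CNc1nc(=O)ccn1[C@@H]1O[C@H](COP(=O)(O)O)[C@@H](O)[C@H]1O`: in an in vitro functional assay on 1321-N1 cells for agonist activity at P2Y purinoceptor 6 (Homo sapiens), read by scintillation proximity assay and inositol phosphate accumulation (a lower number here means that less compound is needed, a higher number that more compound is needed for the effect), compound 1 gives > 100000 nM, a limit of the assay.
Compound 2 `CSc1nc(=O)ccn1[C@@H]1O[C@H](COP(=O)(O)O)[C@@H](O)[C@H]1O`: in this assay compound 2 gives > 100000 nM, a limit of the assay.

In this assay compound 2 therefore stands at a limit of the assay and not at a number. Within the data shown here, the only measured step, a step that the two limits leave unreadable from compound 1 to compound 2, has no readable size because both of its values sit at the limit of > 100000 nM in this assay, at which 2 of the 2 values shown sit. Compound 3 `O=c1ccn([C@@H]2O[C@H](COP(=O)(O)O)[C@@H](O)[C@H]2O)c(SCc2ccccc2)n1` is not yet measured; it differs from compound 2 by phenyl in place of hydrogen on a saturated chain carbon bound to a sulfur. Among the measured compounds shown here, no measured step concerns this change, and the one step that exists carries no readable size, so no direction can be drawn from the numbers. The expected step of a number no higher from compound 2 to compound 3 (the limit leaves the size open) is accordingly set to no change beyond the scatter. Compound 3 is estimated at 100000 nM, within a range from 20000 nM to 300000 nM, and most likely the assay will again report only a limit.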

Compound 3, half-maximal effective concentration: > 100000 nM
Compound 3 gave a limit, no number; the forecaster's own chance of this, stated with the estimate: 70%; the middle value sits exactly at the limit.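

Compound 3 in this assay gives > 100000 nM, again a limit of the assay. Among these compounds, no step among compound 1, compound 2 and compound 3 can be read, because all three stand at the same limit: the limit of > 100000 nM in this assay, at which 3 of the 3 values shown sit.

The compounds shown leave open whether any group on the shared core gives a readable number in this assay.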